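The compounds below may be only part of what the source reports. "The series", "measured", "known", "first", "only" and "open" are said of these compounds alone.

Of the compounds shown here, two have been measured so far in a functional assay on CCRF-CEM cells (Homo sapiens) for antiproliferative activity, read by MTT assay, with a stated time of 48 h, tested at 50 uM; on this read-out lower numbers stand for a stronger effect and higher numbers for a weaker effect at the one concentration tested. Compound 1, with the structure `OC(CCn1nc2c(Br)c(Br)c(Br)c(Br)c2n1)c1cccc(Cl)c1`, gives 0% in this assay. Compound 2, with the structure `C[C@@H](O)CCn1nc2c(Br)c(Br)c(Br)c(Br)c2n1`, gives 23% in this assay, which is the higher of the two numbers and lies beyond the usual scatter above the value of compound 1. Within the data shown here, since the two measured compounds differ in more than one place, no single step between them can be isolated, and so nothing is known yet about how much one defined change to the shared core moves the read-out in this assay.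

Compound 3, with the structure `C[C@H](O)CCn1nc2c(Br)c(Br)c(Br)c(Br)c2n1`, is the next compound to be measured. Compared with compound 2 it differs as follows: the two compounds have the same atoms and bonds and differ only in configuration as drawn: 1 of 1 stereo elements differ; a stereocentre at a saturated chain carbon is drawn R in compound 2 and S in compound 3. Among the measured compounds shown here, with no measured step of this kind available, an expected step from compound 2 to compound 3 is a number 3 percentage points lower from compound 2 to compound 3 (within the scatter), which is expected to lie within the scatter. On that basis compound 3 is estimated to give 20% in this assay, in an expected range from 0% to 45%.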

Compound 3, a percentage reported as activity, at one concentration (the size of the read-out at that concentration, not a potency): 42%
The estimate for compound 3 lay 22 percentage points below the measured number; low and high end bracket the measured number.
By their numbers in this assay, from the lowest: compound 1; then compound 2; then compound 3.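

In this assay, the series now has its first step with a single change, a number 19 percentage points higher from compound 2 to compound 3 (beyond the scatter), and on this read-out a higher number means a weaker effect at the one concentration tested. The handedness of the stereocentre at this saturated chain carbon therefore matters to the read-out: the form drawn R, compound 2, has the stronger effect here, and the form drawn S, compound 3, the weaker one, although the gain or loss is modest in size. Among these compounds, this is the first difference that can be tied to one defined place, and it can be traced to that place alone: the fact that compounds 2 and 3 differ only in the configuration as drawn.

The compounds shown leave open whether the R form would keep its edge over the S form if an amine replaced the hydroxyl group or if a longer chain carried the stereocentre. They also leave open how far the effects of the two forms differ at other concentrations, as a reading at one concentration gives only the size of the effect there, and a single pair of mirror-image forms cannot show a general rule for the series.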